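This account rests on a few compounds, and the source may have more. Where it says the series, first, only, none or still open, it means among the compounds named here.

Of the compounds shown here, two have so far been tested in a functional assay on K562 cells (Homo sapiens) for cytotoxicity, read by trypan blue exclusion, with a stated time of 96 h; a higher number here means a weaker inhibitor, a lower number a stronger inhibitor. Among the measured compounds shown here, compound 1 `COc1cc(OC)c(/C=C/S(=O)(=O)Cc2ccc(F)c([N+](=O)[O-])c2)c(OC)c1` gives 25000 nM in this assay, while compound 2 `COC(=O)CNc1cc(CS(=O)(=O)/C=C/c2c(OC)cc(OC)cc2OC)ccc1OC` gives 100 nM, the lower of the two numbers, with compound 1 its only neighbour and the gap between them well beyond the usual scatter. Compound 3 `COc1cc(OC)c(/C=C/S(=O)(=O)Cc2ccc(OC)c(NC(C(=O)O)c3ccc(F)cc3)c2)c(OC)c1` has not yet been measured; it differs from compound 2 in one place: carboxy(4-fluorophenyl)methyl in place of (methoxycarbonyl)methyl on a nitrogen on an aromatic ring. For the measured compounds named here, no measured pair isolates such a change, so its effect is unknown. The expected step of a 1.5-fold higher number from compound 2 to compound 3 (0.18 log units; within the scatter) is small, staying within the scatter. Compound 3 is expected to give about 150 nM, in a range from 30 nM to 800 nM.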

Compound 3, half-maximal inhibitory concentration: 80 nM
For compound 3 the middle estimate is 1.9-fold (0.27 log units) above the measured one; measured number inside the range.
By their numbers in this assay, from the lowest: compounds 3 and 2 (each within the scatter of the next); then compound 1.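

Placing carboxy(4-fluorophenyl)methyl where (methoxycarbonyl)methyl stood on this nitrogen gives a 1.3-fold lower number from compound 2 to compound 3 (0.10 log units; within the scatter) in this assay. This position on the shared core therefore accepts a larger group carrying a six-membered aromatic ring, with the number staying within the scatter. Nothing at hand explains this result.

As far as these compounds go, because the ester and the added ring differ together, the contribution of each part remains unknown. A carboxymethyl group or an unsubstituted phenyl ring at this position would separate them, and an amide here remains an open case.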